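Sulfonyl ester in place of acetyl on a sugar scaffold

A few compounds are considered here, and "the series" means these few. Any claim that something is new, unique, unknown or untested is made for them only; others in the source may bear on it.

The set centres on a spiro-protected sugar carrying an oxadiazole-bearing aglycone. Compound 1 `COc1cc(C2=NOC(CO[C@@H]3O[C@H](CSc4ncn[nH]4)[C@H]4OC5(CCCC5)O[C@@H]34)C2)cc(OC)c1OC` was tested in a functional assay on SW1573 cells (Homo sapiens) for antiproliferative activity, read by sulforhodamine B assay, with a stated time of 48 h; a higher number here means a weaker inhibitor of growth, a lower number a stronger inhibitor of growth; for compound 1 this assay returns only the limit > 100000 nM, which is a limit and not a number (the limit of > 100000 nM in this assay, at which 1 of the 3 values shown sits). Compound 2 `Nc1nnc(SC[C@H]2O[C@@H](OCc3noc(-c4ccc(Cl)cc4)n3)[C@@H]3OC4(CCCC4)O[C@@H]32)s1` gives 17000 nM in this assay. Within the data shown here, compound 3 `CC(=O)OC[C@H]1O[C@@H](OCc2noc(-c3ccc([N+](=O)[O-])cc3)n2)[C@@H]2OC3(CCCC3)O[C@@H]21` gives 29000 nM in this assay; together with compound 2 it forms the only pair of measured numbers here, and the two values lie within the scatter of each other, so nothing separates them.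

Compound 4 `Cc1ccc(S(=O)(=O)OC[C@H]2O[C@@H](OCc3noc(-c4ccc([N+](=O)[O-])cc4)n3)[C@@H]3OC4(CCCC4)O[C@@H]32)cc1` has not yet been measured. It differs from compound 3 in one place ((4-methylphenyl)sulfonyl in place of acetyl on an oxygen on a saturated carbon). Among the measured compounds shown here, no measured pair among compounds 1 to 3 tracks a change of this kind, so there is no step to lean on. The account therefore rests on compound 3 alone, whose value 29000 nM is the reference. In this assay compound 4 is expected to fall at 12000 nM, between 3000 nM and 45000 nM. The step that this estimate implies is a 2.4-fold lower number from compound 3 to compound 4 (0.38 log units; beyond the scatter), a modest move toward stronger inhibition of growth, though one that could still land within the scatter.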

Compound 4, concentration for 50% growth inhibition: > 100000 nM
Compound 4: only a limit was reported; the forecaster's own chance of this, stated with the estimate: 10%; middle value at least 8.3-fold (0.92 log units) from the limit.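

Among these compounds, the exchange of acetyl for (4-methylphenyl)sulfonyl on an oxygen on a saturated carbon brings an at least 3.4-fold higher number from compound 3 to compound 4 (0.53 log units; beyond the scatter), the first step in this set that tracks a change in one place, and it shows that growth inhibition at this position depends on what the oxygen carries, with the arene-bearing sulfonyl ester on the weaker side of the acetyl ester. In this assay compound 4 returns > 100000 nM, which is a limit and not a number, so the step gives the direction and a lower bound on its size but not its full size. This also means that the upper end of the readable range now holds as many compounds as the measured part of it: the limit of > 100000 nM in this assay, at which 2 of the 4 values shown sit.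

The compounds shown leave open whether any group on this oxygen would improve on acetyl, for instance a free hydroxyl, a methyl ether, a benzoyl ester or an amine in place of the oxygen. They also leave open whether the same exchange would have the same effect with the 4-chlorophenyl group on the oxadiazole instead of the 4-nitrophenyl group, since this single pair is all that speaks to the change.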